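Cytotoxicity notes: amide side-chain trimmed on the shared core

This account rests on a few compounds, and the source may have more. Where it says the series, first, only, none or still open, it means among the compounds named here.

Three compounds of the series are measured in the cytotoxicity test, and all three meet the ceiling of that test. Compound 1 `COc1ccc(-c2c(C)nn3c(NCCNC(=O)C(C)C)cc(C)nc23)cc1OC` is the reference point. In an ADME assay on HeLa cells (Homo sapiens) for cytotoxicity (on this read-out lower numbers stand for higher toxicity in this test and higher numbers for lower toxicity in this test), compound 1 gives > 50000 nM, which is a limit of the assay and not a number. Compound 2 `CC(=O)NCCNc1cc(Cl)nn2c(-c3cccc(S(=O)(=O)NC(C)C)c3)c(C)nc12` belongs to the same set. In this assay compound 2 gives > 50000 nM, again a limit. Compound 3 `CC(=O)NCCNc1cc(Cl)nn2c(-c3ccc(F)c(C=O)c3)c(C)nc12` completes the measured set. In this assay compound 3 gives > 50000 nM, likewise a limit. Within the data shown here, all three values rest at the same point, as summarised in the limit of > 50000 nM in this assay, at which 3 of the 3 values shown sit; no compound stands apart from another, and no step between measured compounds can be read from these values. Compound 4 `COc1ccc(-c2c(C)nn3c(NCCNC(C)=O)cc(C)nc23)cc1OC` is not yet measured. It differs from compound 1 by methyl in place of isopropyl on a carbonyl carbon, in words methyl in place of isopropyl on a carbonyl carbon. Among the measured compounds shown here, no measured step covers a change of this kind, so the expectation rests on the three limits of the set alone. Expected is no step beyond the scatter, a step that the limit leaves unreadable from compound 1 to compound 4. For compound 4 in this assay the expected value is 80000 nM, within 40000 nM to 200000 nM, most likely reported again as a limit.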

Compound 4, half-maximal cytotoxic concentration: > 50000 nM
Compound 4 gave a limit, no number; the forecaster's own chance of this, stated with the estimate: 85%; the middle value lies beyond the limit too.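

No new step can be read between compound 1 and compound 4, since both rest at a limit and the change from isopropylcarbonyl to acetyl therefore has no readable size: the limit of > 50000 nM in this assay, at which 4 of the 4 values shown sit.

The compounds shown leave open whether any member of the series reaches a measurable value in this assay and how the two side-chains would compare there.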